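The source may report more compounds than this note shows. Statements on the series, on what has been measured and on what is new or still open speak of the compounds shown alone.

Among the compounds with values here, compound 3 `CNc1ncnc2c(CNc3cc(NC(=O)c4ccc(Br)s4)ccc3C)cccc12` has the second highest of the three numbers so far in a functional assay on A375P cells (Homo sapiens) for cytotoxicity, read by MTT assay, with a stated time of 24 h (a lower number here means a stronger inhibitor, a higher number a weaker inhibitor), giving 10500 nM. Its nearest neighbour is compound 1 `CNc1ncnc2c(CNc3cc(NC(=O)c4ccc(Cl)c(C(F)(F)F)c4)ccc3C)cccc12`, which in this assay gives 9700 nM, so that the step of a 1.1-fold higher number from compound 1 to compound 3 (0.03 log units; within the scatter) is flat. Furthest away lies compound 2 `CNc1ncnc2c(CNc3cc(NC(=O)c4ccnnc4)ccc3C)cccc12`, which gives 61700 nM; the step of a 5.9-fold lower number from compound 2 to compound 3 (0.77 log units; beyond the scatter) is the only clear movement among the three.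

Compound 4 `CNc1ncnc2c(CNc3cc(NC(=O)c4cscn4)ccc3C)cccc12` arises from compound 3 by the change (1,3-thiazol-4-yl in place of 5-bromothiophen-2-yl on a carbonyl carbon). Within the data shown here, two measured steps bear on it: the flat step a 1.1-fold higher number from compound 1 to compound 3 (0.03 log units; within the scatter), where one ring with a single hetero atom replaced a carbocycle, and the modest step of a 5.9-fold lower number from compound 2 to compound 3 (0.77 log units; beyond the scatter), where a ring with two hetero atoms gave way to the bromothiophene. Since the entering thiazolyl again carries two hetero atoms, the step is expected to resemble a partial reversal of that second one, with a higher number for compound 4 than for compound 3, as a 2.9-fold higher number from compound 3 to compound 4 (0.46 log units; beyond the scatter). Compound 4 is therefore estimated at 30000 nM, within 10000 nM to 90000 nM.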

Compound 4, half-maximal inhibitory concentration: 1900 nM
Compound 4: the middle estimate sits 16-fold (1.20 log units) above what was measured; the measured number lies below the stated range.
By their numbers in this assay, from the lowest: compound 4; then compounds 1 and 3 (each within the scatter of the next); then compound 2.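

On the carbonyl carbon, 1,3-thiazol-4-yl gives the strongest inhibitor of the four in this assay (a 5.5-fold lower number from compound 3 to compound 4 (0.74 log units; beyond the scatter); a 5.1-fold lower number from compound 1 to compound 4 (0.71 log units; beyond the scatter)), showing that this place can carry a number clearly lower than the level shared by compound 1 and compound 3. The largest step at this place is now between two rings with two hetero atoms (a 32-fold lower number from compound 2 to compound 4 (1.51 log units; beyond the scatter)), so the presence of two hetero atoms alone does not set the number. Nothing measured here accounts for the result.

The compounds shown leave open whether 1,3-thiazol-2-yl or 1,3-oxazol-4-yl would hold this number, and whether an amine or a carboxylic acid on the 1,3-thiazol-4-yl would keep it. From the compounds shown here alone, they vary only this one place, so it also remains open whether the step would persist with changes elsewhere in the shared core.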